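Aryl exchange on the core of compound 1

The compounds below may be only part of what the source reports. "The series", "measured", "known", "first", "only" and "open" are said of these compounds alone.

In a functional assay on HL-60 cells (Homo sapiens) for inhibition, read by MTT assay, with a stated time of 72 h (on this read-out higher numbers stand for weaker inhibition and lower numbers for stronger inhibition), compound 1 `Cc1nc(-c2ccc(F)cc2)c(C(=O)N2CCN(c3cccc(Cl)c3)CC2)o1` gives 40.1 nM. Compound 2 `Cc1nc(-c2ccc(F)cc2)c(C(=O)N2CCN(c3cc(Cl)cc(Cl)c3)CC2)o1` gives 52.1 nM, and the two cannot be told apart. Compound 3 `O=C(c1oc(C(F)(F)F)nc1-c1ccc(F)cc1)N1CCN(c2cccc(Cl)c2)CC1` is reported as "not active" (no number reported), with no number. Going by the values given here, compound 1 therefore stands level with compound 2 among the only two numbers available.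

Among the compounds with values here, the only measured step is a 1.3-fold higher number from compound 1 to compound 2 (0.11 log units; within the scatter), chloro in place of hydrogen on an aromatic carbon. It lies at a different place in the molecule from the change considered here, and it stays within the scatter.

Compound 4 `COc1ccc(-c2nc(C)oc2C(=O)N2CCN(c3cccc(Cl)c3)CC2)cc1O` keeps the rest of compound 1 and alters one aryl group: 3-hydroxy-4-methoxyphenyl in place of 4-fluorophenyl on an aromatic carbon. Within the data shown here, no measured compound varies this position, so the size of the step has no direct precedent. The flat step to compound 2 says little about it, and the missing number for compound 3 shows that activity is not assured in this small set.

A moderate loss is the working expectation, with no change also plausible. The expected shift is a 2.2-fold higher number from compound 1 to compound 4 (0.35 log units; beyond the scatter), and this estimate is loosely held. For compound 4 the estimated value is 90 nM, with an expected range of 15 nM to 600 nM.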

Compound 4, half-maximal inhibitory concentration: "not active" (no number reported)
No number was reported for compound 4, so the estimate cannot be set against anything.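

Going by these compounds alone, compound 4, like compound 3, is reported as "not active" without a number in this assay, so no step from compound 1 to compound 4 can be read. No available evidence bears on this result. The compounds shown leave open whether any aryl group other than 4-fluorophenyl on the shared core gives a numerical value.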